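Widening the aryl ether in a receptor agonist series

The source may hold more compounds than are shown below. What is called first, only, known or untested is meant among the compounds shown, and "the series" means these compounds.

Measured so far in a functional assay on HEK293 cells for agonist activity at G-protein coupled receptor 39 (Homo sapiens), read by scintillation proximity assay and inositol phosphate accumulation, with a stated time of 75 min, in the presence of a further agent that is not named here; a lower number here means that less compound is needed, a higher number that more compound is needed for the effect:
Compound 1 `Cc1nn(-c2ncnc3nc[nH]c23)c2c1C(OCc1ccccc1F)CC(=O)N2` gives 4 nM.
Compound 2 `Cc1nn(-c2ncnc3nc[nH]c23)c2c1C(C(=O)N(C)c1nccs1)CC(=O)N2` gives 18 nM.
Compound 3 `Cc1nn(-c2ncnc3nc[nH]c23)c2c1C(C(=O)N(C)c1ccccc1)CC(=O)N2` gives 32 nM.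

Compound 1 has the lowest number of the three. The step of a 4.5-fold higher number from compound 1 to compound 2 (0.65 log units; beyond the scatter) and the step of an 8.0-fold higher number from compound 1 to compound 3 (0.90 log units; beyond the scatter) both lie beyond the scatter, so each measured change away from compound 1 made more compound necessary. Between the two carbamoyl compounds the step of a 1.8-fold higher number from compound 2 to compound 3 (0.25 log units; within the scatter) lies within the scatter.

Compound 4 `Cc1nn(-c2ncnc3nc[nH]c23)c2c1C(OCc1cc(F)cc3c1OCOC3)CC(=O)N2` differs from compound 1 in one place: a group of 11 heavy atoms (8 carbon, 2 oxygen, 1 fluorine; one six-membered non-aromatic ring with 2 hetero atoms, one six-membered aromatic ring of carbon only) in place of a group of 7 heavy atoms (6 carbon, 1 fluorine; one six-membered aromatic ring of carbon only), on a saturated chain carbon bound to an oxygen on a saturated carbon. The ether link of compound 1 is kept; the aromatic part hanging on it is enlarged by a fused non-aromatic ring. Neither measured step tests this kind of change: both a 4.5-fold higher number from compound 1 to compound 2 (0.65 log units; beyond the scatter) and an 8.0-fold higher number from compound 1 to compound 3 (0.90 log units; beyond the scatter) swapped the whole (2-fluorobenzyl)oxy group for an amide-type group. Going by the values given here, they show only that this ether group gives the lowest number of the groups tried, not how an addition to it behaves. Among the compounds with values here, with no closely matching precedent, the expected step is about a 1.5-fold higher number from compound 1 to compound 4 (0.18 log units; within the scatter), most likely within the scatter, with some chance of a higher number. The estimate for compound 4 is 6 nM, with a range from 1.5 nM to 25 nM.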

Compound 4, half-maximal effective concentration: 1.5 nM
For compound 4 the middle estimate is 4.0-fold (0.60 log units) above the measured one, and the stated range covers the measured number.
By their numbers in this assay, from the lowest: compound 4; then compound 1; then compounds 2 and 3 (each within the scatter of the next).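

In this assay, keeping the ether link and enlarging the aromatic part gives a 2.7-fold lower number from compound 1 to compound 4 (0.43 log units; beyond the scatter), so this position can hold a larger group than the 2-fluorophenyl of compound 1 and still improve on it. The earlier steps replaced the whole ether group and showed only a rise in the number, whereas this is the first change shown that lowers it, and compound 1 is therefore not the best this position can offer. No measurement shown here explains this difference between compound 1 and compound 4.

The new ring and its oxygen atoms enter together, so this one step cannot say which of them matters. Also open, going by these compounds, is how a methoxy group on the 2-fluorophenyl ring, a longer chain after the ether oxygen, or an amine in place of that oxygen would behave.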